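From Thiophen-2-yl to Penta-1,3-dien-1-yl on a Carbonyl Carbon

The source may hold more compounds than are shown below. What is called first, only, known or untested is meant among the compounds shown, and "the series" means these compounds.

Of the compounds shown here, three sharing a core have been tested in a functional assay on MCF7 cells (Homo sapiens) for cytotoxicity, read by MTT assay, with a stated time of 48 h; on this read-out lower numbers stand for stronger inhibition and higher numbers for weaker inhibition. Compound 1 `CCCCCCCCNC(=O)[C@@H](NC(=O)c1ccco1)[C@@H](C)O` gives 91800 nM. Compound 2 `CCCCCCCCNC(=O)[C@@H](NC(=O)c1cccs1)[C@@H](C)O` gives 72500 nM, and compound 3 `CCCCCCCCNC(=O)[C@@H](NC(=O)c1nccc2ccccc12)[C@@H](C)O` gives 63200 nM. Among these three numbers compound 2 holds the second highest, yet its gaps to compound 3 and to compound 1 both lie within the scatter, so the three cannot be told apart on this read-out. Within the data shown here, the one single-point step measured so far, a 1.3-fold lower number from compound 1 to compound 2 (0.10 log units; within the scatter), exchanges one five-membered aromatic ring for another and moves nothing beyond the scatter.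

Compound 4 `C/C=C/C=C/C(=O)N[C@H](C(=O)NCCCCCCCC)[C@@H](C)O` differs from compound 2 by penta-1,3-dien-1-yl in place of thiophen-2-yl on a carbonyl carbon. Among the measured compounds shown here, no measured step replaces a ring with an open chain, so the only guidance is the indifference seen in a 1.3-fold lower number from compound 1 to compound 2 (0.10 log units; within the scatter) and the narrow spread of all three values. Compound 4 is therefore expected to stay close to compound 2, with a 1.0-fold lower number from compound 2 to compound 4 (0.02 log units; within the scatter) expected to be no larger than the scatter. The estimate for compound 4 in this assay is 70000 nM, within a range from 30000 nM to 170000 nM.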

Compound 4, half-maximal inhibitory concentration: 149000 nM
The estimate for compound 4 lay 2.1-fold (0.33 log units) below the measured number; the range from low to high includes it.
By their numbers in this assay, from the lowest: compounds 3, 2, 1 and 4 (each within the scatter of the next, the first and the last beyond it).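

In this assay this position on a carbonyl carbon now shows its first step beyond the scatter, when the open penta-1,3-dien-1-yl chain takes the place of the thiophen-2-yl ring (a 2.1-fold higher number from compound 2 to compound 4 (0.31 log units; beyond the scatter)). The same chain in place of furan-2-yl stays within the scatter (a 1.6-fold higher number from compound 1 to compound 4 (0.21 log units; within the scatter)), so the change from ring to open chain is only a modest one and is resolved against just one of the two five-membered aromatic rings. No evidence is at hand that accounts for this result.

Still open, as far as these compounds go, is whether a saturated pentyl chain on this carbonyl carbon would read like compound 4, which would separate the loss of the ring from the presence of the double bonds. Also open, from the compounds shown here alone, is how a chain ending in an amine or a carboxylic acid would read at this position in this assay.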